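Methylation of a Phenol and Tolerated Concentration in Liver Cells

This account rests on a few compounds, and the source may have more. Where it says the series, first, only, none or still open, it means among the compounds named here.

In an ADME assay on HepG2 cells (Homo sapiens) for cytotoxicity, read by resazurin assay, with a stated time of 24 h (a higher number here means that more compound is tolerated, a lower number that less compound is tolerated), compound 1 `O=C(O)c1c(O)cc(Cl)cc1C=Cc1ccc2ccccc2c1` gives 25000 nM. Compound 2 `COc1cc(Cl)cc(C=Cc2ccc3ccccc3c2)c1C(=O)O` differs from compound 1 by methyl in place of hydrogen on an oxygen on an aromatic ring, and in this assay compound 2 gives 104000 nM, so that a 4.2-fold higher number from compound 1 to compound 2 (0.62 log units; beyond the scatter). Compound 3 `CCN(CC)C(=O)c1c(O)cccc1CCc1ccc2ccccc2c1` stands on a different core, and the difference between the two cores is not broken down here. In this assay compound 3 reaches only the limit of the measurement, > 100000 nM, which is the limit of > 100000 nM in this assay, at which 1 of the 3 values shown sits. Compound 4 `CCN(CC)C(=O)c1c(CCc2ccc3ccccc3c2)cccc1OC` differs from compound 3 by methyl in place of hydrogen on an oxygen on an aromatic ring, the same change as from compound 1 to compound 2, at a place described in the same words. In this assay the expected step is a step that the limit leaves unreadable from compound 3 to compound 4. This expectation rests on the direction of a 4.2-fold higher number from compound 1 to compound 2 (0.62 log units; beyond the scatter) and on compound 3 already standing at the limit of > 100000 nM in this assay, at which 1 of the 3 values shown sits, so that a limit rather than a number is the likely report once more. Compound 4 is therefore estimated at 150000 nM, between 50000 nM and 600000 nM.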

Compound 4, half-maximal cytotoxic concentration: 35800 nM
Beside the measured number, compound 4's estimate is 4.2-fold (0.62 log units) above it; the whole stated range lies above it.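

In this assay, the change from hydroxy to methoxy now gives an at least 2.7-fold lower number from compound 3 to compound 4 (0.44 log units; beyond the scatter), so the direction of the earlier step did not carry over from one core to the other: the same change on two cores in this assay, a 4.2-fold higher number (0.62 log units; beyond the scatter) from compound 1 to compound 2 and an at least 2.7-fold lower number (0.44 log units; beyond the scatter) from compound 3 to compound 4, at least 11-fold (1.06 log units) apart, beyond the scatter of two such steps. The value of compound 3, > 100000 nM, is a limit of the assay and not a number, so the size of the new step is known only as a bound: the limit of > 100000 nM in this assay, at which 1 of the 4 values shown sits. The result shows that, in this small set, the effect of this methylation depends on the core, but with one pair on each core it does not show which of the differences between the cores goes with the reversal, nor why the two steps part.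

The compounds shown leave open how an ethoxy group or a longer chain on the same oxygen would behave on each core. They also leave open whether an amine at that place would follow either step.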